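The compounds below may be only part of what the source reports. "The series", "measured", "known", "first", "only" and "open" are said of these compounds alone.

Compound 1 `Cc1ccccc1-n1nc(C)c2c1NC(=O)[C@H](C)S[C@@H]2c1ccc(-c2cc3ccccc3o2)cc1` and compound 2 `CCOc1cccc(-c2ccc([C@H]3S[C@@H](C)C(=O)Nc4c3c(C)nn4-c3ccccc3C)cc2)c1` share a core with compound 3 `Cc1ccccc1-n1nc(C)c2c1NC(=O)[C@H](C)S[C@@H]2c1ccc(Oc2ccc(C(=O)O)cc2)cc1`; they differ only in the group attached to the outer aromatic ring. In an assay on isolated protein for agonist activity at Bile acid receptor (Homo sapiens), read by AlphaScreen, with a stated time of 30 min (a higher number here means that more compound is needed for the effect, a lower number that less compound is needed), compound 1 gives 1500 nM, and compound 2 gives 3500 nM. The step of a 2.3-fold higher number from compound 1 to compound 2 (0.37 log units; beyond the scatter) shows that exchanging one directly attached aromatic group for another moves the number only modestly. Compound 3 carries a 4-carboxyphenoxy group instead, and in this assay compound 3 is reported as "not active" (no number reported), so no single number is known for it; it stands apart from the two compounds that do give numbers.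

Compound 4 `COC(=O)c1ccc(-c2ccc([C@H]3S[C@@H](C)C(=O)Nc4c3c(C)nn4-c3ccccc3C)cc2)cc1` is the next step. Its change from compound 3 is 4-(methoxycarbonyl)phenyl in place of 4-carboxyphenoxy on an aromatic carbon. Among the compounds with values here, no measured step covers this exact change. What is known is that the two compounds with a directly attached aromatic group, compound 1 and compound 2, gave numbers in this assay, and their step was modest, while the compound with the 4-carboxyphenoxy group did not give a number. Compound 4 again has a directly attached aromatic group, so a number in the region of compound 1 and compound 2 is expected. Compound 4 is therefore estimated at 3000 nM, within a range from 800 nM to 15000 nM.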

Compound 4, half-maximal effective concentration: "not active" (no number reported)
Compound 4: no number reported, and the estimate cannot be compared.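

In this assay compound 3 and compound 4 are both reported without a number, so no step can be read between them. The compounds shown leave open what separates compound 4, with its directly attached aromatic group, from compound 1 and compound 2, which do give numbers. No evidence given here bears on this result.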